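The compounds below may be only part of what the source reports. "The series", "measured", "known", "first", "only" and "open" are said of these compounds alone.

Working notes on the series.

Of the compounds shown here, three of one shared core have been measured in a functional assay on P388 cells (Mus musculus) for cytotoxicity, read by MTT assay, with a stated time of 72 h; a lower number here means a stronger inhibitor, a higher number a weaker inhibitor. Compound 1 `COc1ccc(/C=N/c2c(C)n(C)n(-c3ccccc3)c2=O)cc1` gives 186000000 nM. Compound 2 `COc1cccc(/C=N/c2c(C)n(C)n(-c3ccccc3)c2=O)c1` gives 105000000 nM, and the step of a 1.8-fold lower number from compound 1 to compound 2 (0.25 log units; within the scatter) keeps the two within the usual scatter, so no order between them is claimed. Compound 3 `COc1cc(/C=N/c2c(C)n(C)n(-c3ccccc3)c2=O)ccc1O` gives 316000000 nM; the step of a 3.0-fold higher number from compound 2 to compound 3 (0.48 log units; beyond the scatter) is modest but beyond the scatter. Compound 2 therefore stands at the lowest number of the three, with compound 1 closest and compound 3 furthest.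

The step under consideration goes from compound 2 to compound 4 `Cc1c(/N=C/c2ccccc2)c(=O)n(-c2ccccc2)n1C`, not yet measured in this assay. The change is hydrogen in place of methoxy on an aromatic carbon. Among the compounds with values here, two measured steps bear on it. The shift of the methoxy from compound 1 to compound 2 was within the scatter, which suggests that where the methoxy sits matters little; the added hydroxy from compound 2 to compound 3 raised the number beyond the scatter, showing that a change on the same ring can register. Removing the methoxy altogether is not covered directly by any measured pair, so the expectation is a small step, if any, with a slight lean toward a higher number.

Compound 4 is therefore expected to give 150000000 nM, within 60000000 nM to 400000000 nM, the expected step being a 1.4-fold higher number from compound 2 to compound 4 (0.15 log units; within the scatter).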

Compound 4, half-maximal inhibitory concentration: 240000000 nM
Beside the measured number, compound 4's estimate is 1.6-fold (0.20 log units) below it; measured number inside the range.
By their numbers in this assay, from the lowest: compounds 2, 1, 4 and 3 (each within the scatter of the next, the first and the last beyond it).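

In this assay, removing the methoxy from the 3-methoxyphenyl gives a 2.3-fold higher number from compound 2 to compound 4 (0.36 log units; beyond the scatter), so a step on this ring that deletes the group registers, which the earlier move of the methoxy did not show. The same change starting from the 4-methoxyphenyl gives a 1.3-fold higher number from compound 1 to compound 4 (0.11 log units; within the scatter) and stays within the scatter; since compound 1 and compound 2 are themselves within the scatter of each other, this contrast does not establish that one placement of the methoxy matters more than the other. No measurement on hand accounts for either step, so the size of the change at this position stands as an observation with no explanation attached.

Going by these compounds, whether an amine or a carboxylic acid on this aromatic carbon, or an ethoxy as a longer chain in place of the methoxy, would move the number well away from the values seen so far remains open. Also open is what the hydroxy of compound 3 would do on the phenyl of compound 4 with no methoxy present, since the only hydroxy step shown has the methoxy alongside it.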